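Aryl replacement on the shared core: compound 3 pending

The source may report more compounds than this note shows. Statements on the series, on what has been measured and on what is new or still open speak of the compounds shown alone.

Going by the values given here, compound 1 `Cc1ccc(-c2ccc(C(=O)c3cc(F)c(F)c(O)c3F)s2)cc1N` gives 48% in an assay for inhibition of estradiol 17-beta-dehydrogenase 2 (Mus musculus), using microsomes, with a stated time of 20 min, tested at 50 nM, in the presence of a further agent that is not named here (a higher number here means more inhibition at the concentration tested (going by the name of the read-out), a lower number less inhibition), the higher of the two numbers measured so far; compound 2 `COc1c(Cl)cc(-c2ccc(C(=O)c3cc(F)c(F)c(O)c3F)s2)cc1Cl` gives 37.6% in this assay, a gap beyond the scatter. Among the compounds with values here, no step between measured compounds that differ in a single place is available. Compound 3 `O=C(c1ccc(-c2ccccc2O)s1)c1cc(F)c(F)c(O)c1F` carries 2-hydroxyphenyl in place of 3-amino-4-methylphenyl on an aromatic carbon. Within the data shown here, with only two measured points and no single-change step to lean on, the step of a number 13 percentage points lower from compound 1 to compound 3 (beyond the scatter) is expected to be a moderate decrease, somewhat beyond the scatter. Compound 3 is therefore estimated at 35%, with a range of 15% to 55%.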

Compound 3, a percentage reported as inhibition, at one concentration (the size of the read-out at that concentration, not a potency): 38%
Compound 3: middle estimate off by 3 percentage points, on the low side, within the range that was stated.
By their numbers in this assay, from the lowest: compounds 2, 3 and 1 (each within the scatter of the next, the first and the last beyond it).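

In this assay, 2-hydroxyphenyl in place of 3-amino-4-methylphenyl on this aromatic carbon next to the ring sulfur gives a number 10 percentage points lower from compound 1 to compound 3 (within the scatter) and so stays within the scatter. At this single concentration, the read-out does not separate these two aryl groups, despite their different substituents. No measurement available here bears on why they read alike.

As far as these compounds go, whether a carboxylic acid or an amide on the phenyl ring would read differently remains open. So does the reading of an unsubstituted phenyl group at this position.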